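Ethoxypyridine for methoxypyrimidine on the thiazole-bearing aryl position

A few compounds are considered here, and "the series" means these few. Any claim that something is new, unique, unknown or untested is made for them only; others in the source may bear on it.

The series is followed in an assay on blood for inhibition of C-X-C chemokine receptor type 3 (Homo sapiens), with a stated time of 30 min; a lower number here means a stronger inhibitor, a higher number a weaker inhibitor. Compound 1 `CCOc1ncc(-c2nc(C(F)(F)F)sc2N2CCN(C(=O)Cn3cnc4cccnc43)[C@H](C)C2)cn1` gives 48 nM. Compound 2 `COc1ncc(-c2nc(C(F)(F)F)sc2N2CCN(C(=O)Cn3nc(C)nc3C)[C@H](C)C2)cn1` gives 1040 nM, the higher of the two numbers recorded so far; its nearest neighbour is compound 1, whose number lies well below it, beyond the usual scatter. Among the compounds with values here, compounds 1 and 2 differ in more than one place, so no single step between them can be read off, and the two values are taken only as they stand.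

Compound 3 `CCOc1ccc(-c2nc(C(F)(F)F)sc2N2CCN(C(=O)Cn3nc(C)nc3C)[C@H](C)C2)cn1` is not yet measured. It differs from compound 2 in one place: 6-ethoxypyridin-3-yl in place of 2-methoxypyrimidin-5-yl on an aromatic carbon. The carried-over amide side chain of compound 2 stays in place, so the change is confined to the aryl group.

Within the data shown here, no measured pair isolates this change. Among the measured compounds shown here, the alkoxy group of compound 1, which gives 48 nM, is the same as the one entering in compound 3, which is taken as mild support for a lower number. The step from compound 2 to compound 3 is expected to be a moderate decrease, a 2.6-fold lower number from compound 2 to compound 3 (0.41 log units; beyond the scatter), direction uncertain at the edges. Compound 3 is estimated at 400 nM, with a range from 120 nM to 1500 nM.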

Compound 3, half-maximal inhibitory concentration: 887 nM
Beside the measured number, compound 3's estimate is 2.2-fold (0.35 log units) below it, within the range that was stated.
By their numbers in this assay, from the lowest: compound 1; then compounds 3 and 2 (each within the scatter of the next).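

In this assay, within the data shown here, this is the first comparison that isolates the aryl group on this aromatic carbon, and it gives a 1.2-fold lower number from compound 2 to compound 3 (0.07 log units; within the scatter). With the amide side chain of compound 2 held fixed, compound 2 and compound 3 cannot be told apart, even though the ring hetero atoms and the alkoxy chain differ together in this one change. No measurement on hand bears on this result, and steps to compound 1 cannot be read because it differs from compound 2 and compound 3 in more than one place.

The ring and the alkoxy chain remain unseparated, so 6-methoxypyridin-3-yl on the same side chain would be needed to show whether the two parts of the change contribute separately or simply offset one another. Also open, as far as these compounds go, is whether the two aryl groups stay equivalent on the amide side chain of compound 1, and whether this position accepts a longer chain such as propoxy or an amine such as dimethylamino in place of the ethoxy group.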